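Swapping an aromatic group for a short amine chain

The compounds below may be only part of what the source reports. "The series", "measured", "known", "first", "only" and "open" are said of these compounds alone.

Measured so far:
compound 1 `CCCCNc1nc(N)nnc1OCc1ccccc1F` gives 560 nM
compound 2 `CCC[C@H](CCO)Nc1nc(N)nnc1OCc1nccc(OC)c1OC` gives 560 nM

In an assay on isolated protein for agonist activity at Toll-like receptor 8 (Homo sapiens) (a higher number here means that more compound is needed for the effect, a lower number that less compound is needed), compound 1 gives 560 nM, and compound 2 gives 560 nM, so compound 1 stands level with compound 2 within the scatter. Compound 3 `CCCCNc1nc(N)nnc1OCCCN(C)C` has not been measured in this assay; it differs from compound 1 by 2-(dimethylamino)ethyl in place of 2-fluorophenyl on a saturated chain carbon bound to an oxygen on an aromatic ring. Within the data shown here, no measured pair in this set shows what such a change does. A modest loss is expected, so compound 3 is estimated at 1500 nM, with a range from 400 nM to 6000 nM, which means an expected step of a 2.7-fold higher number from compound 1 to compound 3 (0.43 log units; beyond the scatter).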

Compound 3, half-maximal effective concentration: 100 nM
Compound 3: middle estimate off by 15-fold (1.18 log units), on the high side; measured number below the stated range.
By their numbers in this assay, from the lowest: compound 3; then compounds 1 and 2 (each within the scatter of the next).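

In this assay, an aromatic ring is not required on the saturated chain carbon bound to an oxygen on an aromatic ring: 2-(dimethylamino)ethyl in place of 2-fluorophenyl gives a 5.6-fold lower number from compound 1 to compound 3 (0.75 log units; beyond the scatter). Compounds 1 and 2 differ in more than one place, so they could not show what a single change here does. No measurement at hand explains this step.

Going by these compounds, whether the step depends on the nitrogen or on losing the ring remains open, and a plain butyl chain here would help separate the two. A carboxylic acid or a longer chain ending in dimethylamino would show how far the group can vary.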